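The compounds below may be only part of what the source reports. "The series", "measured", "known", "first", "only" and "open" are said of these compounds alone.

Measured so far in a functional assay on MDA-MB-231 cells (Homo sapiens) for cytotoxicity, read by MTT assay, with a stated time of 24 h; on this read-out lower numbers stand for stronger inhibition and higher numbers for weaker inhibition:
- compound 1 `Fc1ccc(-c2nc3cccnc3n2C2CCCC2)cc1`: 500 nM
- compound 2 `O=C(O)c1ccc(-c2nc3cccnc3n2C2CCCC2)cc1`: 600 nM

Within the data shown here, compound 1 cannot be separated from its only measured neighbour, since the one available step is a 1.2-fold higher number from compound 1 to compound 2 (0.08 log units; within the scatter). Compound 3 `Cc1ccsc1-c1nc2cccnc2n1C1CCCC1` has 3-methylthiophen-2-yl in place of 4-fluorophenyl on an aromatic carbon. The measured step exchanged only fluoro for carboxy, so no data cover replacing the whole ring, and the estimate stays wide. No shift beyond the scatter is expected in this assay, and the expected step is a 1.4-fold higher number from compound 1 to compound 3 (0.15 log units; within the scatter). For compound 3 the expected value is 700 nM, with an estimated range of 200 nM to 2500 nM.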

Compound 3, half-maximal inhibitory concentration: 138 nM
The estimate for compound 3 lay 5.1-fold (0.71 log units) above the measured number; measured number below the stated range.
By their numbers in this assay, from the lowest: compound 3; then compounds 1 and 2 (each within the scatter of the next).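

In this assay, the aromatic carbon next to the ring atom that bears a cyclopentyl group responds to a change of the whole ring: 3-methylthiophen-2-yl in place of 4-fluorophenyl gives a 3.6-fold lower number from compound 1 to compound 3 (0.56 log units; beyond the scatter). Among these compounds, exchanging only fluoro for carboxy had given no shift beyond the scatter, so this is the first step at this position that can be read. Nothing available accounts for the step.

The ring and the methyl change together, so their shares remain unseparated. Plain thiophen-2-yl, without the methyl group, would separate them, and how an amine on the ring would fare remains open.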